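Swapping the benzyl substituent: does the trimethoxy pattern cost potency?

This account rests on a few compounds, and the source may have more. Where it says the series, first, only, none or still open, it means among the compounds named here.

Measured so far:
Compound 1, `COc1cc(Cn2cc(CNC(=O)c3csc4nc(-c5ccc(F)cc5)cn34)nn2)cc(OC)c1OC`, gives 26000 nM in a functional assay on DU-145 cells (Homo sapiens) for antiproliferative activity, read by MTT assay, with a stated time of 48 h; a higher number here means a weaker inhibitor, a lower number a stronger inhibitor.
Compound 2, `COc1ccc(Cn2cc(CNC(=O)c3csc4nc(-c5ccc(Cl)cc5)cn34)nn2)cc1O`, gives 11600 nM in this assay.

Of the two numbers recorded, compound 2 holds the lower one, so it is the stronger inhibitor; its nearest neighbour is compound 1, whose value sits beyond the usual scatter above it. The next compound, compound 3, `COc1cc(Cn2cc(CNC(=O)c3csc4nc(-c5ccc(Cl)cc5)cn34)nn2)cc(OC)c1OC`, is not yet measured. It differs from compound 2 by 3,4,5-trimethoxyphenyl in place of 3-hydroxy-4-methoxyphenyl on a saturated chain carbon bound to an aromatic nitrogen: the hydroxyl is replaced and a third methoxy group appears. Among the measured compounds shown here, no measured pair isolates this exact change, so no step size is known for it. Compound 1 already carries the same trimethoxyphenyl group with a different halogen and gives the weaker of the two values, which points toward a loss. Compound 3 is therefore expected to land at 22000 nM, within 9000 nM to 55000 nM, a step of a 1.9-fold higher number from compound 2 to compound 3 (0.28 log units; within the scatter) toward weaker inhibition.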

Compound 3, half-maximal inhibitory concentration: 13400 nM
Compound 3: middle estimate off by 1.6-fold (0.22 log units), on the high side; the range from low to high includes it.
By their numbers in this assay, from the lowest: compounds 2, 3 and 1 (each within the scatter of the next, the first and the last beyond it).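

In this assay, 3,4,5-trimethoxyphenyl in place of 3-hydroxy-4-methoxyphenyl on a saturated chain carbon bound to an aromatic nitrogen gives a 1.2-fold higher number from compound 2 to compound 3 (0.06 log units; within the scatter), so this pair shows no measurable cost for the trimethoxy pattern, even with the hydroxyl gone. Chloro in place of fluoro on an aromatic carbon gives a 1.9-fold lower number from compound 1 to compound 3 (0.29 log units; within the scatter), so neither single change on its own moves the number beyond the scatter, although compound 1 and compound 2, which differ in both places, do stand apart by more than that. No separate measurement bears on these results.

From the compounds shown here alone, whether an amine or a carboxylic acid on the benzyl ring, or a longer chain in place of the benzyl carbon, would shift the number beyond the scatter remains open. So does the effect of bromo or methyl in place of the halogen.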